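The compounds below may be only part of what the source reports. "The series", "measured", "known", "first", "only" and "open" are said of these compounds alone.

Two measured compounds frame this series. In a functional assay on BaF3 cells (Mus musculus) for inhibition, read by CCK-8 assay, with a stated time of 72 h (a higher number here means a weaker inhibitor of growth, a lower number a stronger inhibitor of growth), compound 1 `CCN1CCN(Cc2ccc(NC(=O)Nc3ccc(Oc4cc(NC(C)=O)ncn4)cc3)cc2C(F)(F)F)CC1` gives 38 nM. Compound 2 `Cc1ccc(NC(=O)Nc2ccc(Oc3cc(/N=C/N(C)C)ncn3)cc2)cc1C(F)(F)F` gives 6610 nM, the higher of the two numbers and beyond the scatter from compound 1. Compound 3 `Cc1ccc(NC(=O)Nc2ccc(Oc3cc(N4CCN[C@H](C)C4)ncn3)cc2)cc1C(F)(F)F` keeps the rest of compound 2 and changes one substituent on the six-membered aromatic ring with 2 nitrogen: a group of 7 heavy atoms (5 carbon, 2 nitrogen; one six-membered non-aromatic ring with 2 hetero atoms) in place of a group of 5 heavy atoms (3 carbon, 2 nitrogen; no ring), on an aromatic carbon. The entering group is 3-methylpiperazin-1-yl, on an aromatic carbon. Among the measured compounds shown here, no measured pair differs in only one place, so nothing here sizes this change directly. With compound 2 at 6610 nM, a moderate step in this assay toward a lower number is expected, probably beyond the scatter, though the uncertainty is wide. The estimated change is a 4.4-fold lower number from compound 2 to compound 3 (0.64 log units; beyond the scatter). Compound 3 is expected at 1500 nM, with an estimated range of 300 nM to 6000 nM.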

Compound 3, concentration for 50% growth inhibition: 8920 nM
Compound 3: middle estimate off by 5.9-fold (0.77 log units), on the low side, outside the stated range (above it).
By their numbers in this assay, from the lowest: compound 1; then compounds 2 and 3 (each within the scatter of the next).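

In this assay, replacing the open-chain group with 3-methylpiperazin-1-yl on the aromatic carbon next to the ring nitrogen gives a 1.3-fold higher number from compound 2 to compound 3 (0.13 log units; within the scatter). Among the compounds shown here, this is the first single-place comparison, and it shows that adding a non-aromatic ring, a hydrogen-bond donor and a defined stereocentre at this position leaves the read-out within the scatter. No supporting measurement speaks to why the two groups read alike.

Still open, from the compounds shown here alone, is whether a morpholine or a plain primary amine at this position would separate from these two groups, and whether the opposite enantiomer of 3-methylpiperazin-1-yl would match compound 3. Compound 1 differs from both compounds in more than one place, so the contribution of this position to its value remains unresolved.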